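The source may report more compounds than this note shows. Statements on the series, on what has been measured and on what is new or still open speak of the compounds shown alone.

Working notes on the series. Three compounds carry numbers in an in vivo ADME assay on the whole organism for pharmacokinetics, with Rattus norvegicus as the target, at a dose of 5 mg/kg by the oral route; a higher number here means that a larger share of the oral dose reaches the circulation, a lower number that a smaller share of the oral dose reaches the circulation. Compound 1 `CC[C@H](C)[C@@H]1C(=O)N[C@H](C2Cc3ccccc3C2)C(=O)N1[C@@H](C(=O)N1CCOCC1)c1ccc(C)nc1` gives 54%. Compound 2 `CCC(CC)[C@@H]1C(=O)N[C@H](C2Cc3ccccc3C2)C(=O)N1[C@@H](C(=O)N1CCOCC1)c1ccc(C)nc1C` gives 42%. Compound 3 `COc1ccc([C@H](C(=O)N(C)C)N2C(=O)[C@@H](C3Cc4ccccc4C3)NC(=O)[C@H]2CC(C)C)cn1` gives 62%, and the gap to compound 1 sits within the usual scatter, so no order between those two is claimed. Against compound 2, however, compound 3 sits clearly above, the gap being beyond the scatter. Going by the values given here, no single-point step between measured compounds exists, so the series offers no precedent for the change now in view.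

Compound 4 `Cc1ccc([C@H](C(=O)N(C)C)N2C(=O)[C@@H](C3Cc4ccccc4C3)NC(=O)[C@H]2CC(C)C)cn1` differs from compound 3 in one place: methyl in place of methoxy on an aromatic carbon

Among the compounds with values here, with no measured precedent for this change, the step from compound 3 to compound 4 is expected to be small, a number 7 percentage points lower from compound 3 to compound 4 (within the scatter), none beyond the scatter. Compound 4 is thus estimated at 55%, with a range from 35% to 75%.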

Compound 4, oral bioavailability: 57%
Compound 4: the middle estimate sits 2 percentage points below what was measured; the measured number falls inside the stated range.
By their numbers in this assay, from the lowest: compound 2; then compounds 1, 4 and 3 (each within the scatter of the next).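

Going by these compounds alone, at the position on an aromatic carbon next to the ring nitrogen, methyl in place of methoxy gives, in this assay, a number 5 percentage points lower from compound 3 to compound 4 (within the scatter), the only single-point step. Methoxy is therefore not required at this position for a number of this size. Nothing measured in the series accounts for this result.

Open, going by these compounds, is how an amine, a chlorine or a longer chain such as ethoxy would read at this position. Also open, on these data alone, is whether the step holds with the other groups on the shared core, such as the morpholine amide of compound 1.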